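From allyloxy to amino on a carbonyl carbon

This account rests on a few compounds, and the source may have more. Where it says the series, first, only, none or still open, it means among the compounds named here.

Measured so far in a functional assay on A549 cells (Homo sapiens) for antiproliferative activity, read by MTT assay; a lower number here means a stronger inhibitor, a higher number a weaker inhibitor:
- compound 1 (`CC(C)COC(=O)N1CCCc2cc(S(=O)(=O)N3CC(c4ccccc4)NC3=O)ccc21`) gives > 20000 nM as a limit of the assay
- compound 2 (`C=CCOC(=O)N1CCCc2cc(S(=O)(=O)N3CC(c4ccccc4)NC3=O)ccc21`) gives 4310 nM as a number

For the measured compounds named here, compound 2 holds the only true number, and the other result is a limit. Compound 3 (`NC(=O)N1CCCc2cc(S(=O)(=O)N3CC(c4ccccc4)NC3=O)ccc21`) carries amino in place of allyloxy on a carbonyl carbon and keeps the rest of the core. Going by the values given here, one measured step bears on this only indirectly (an at least 4.6-fold lower number from compound 1 to compound 2 (0.66 log units; beyond the scatter)), with vinyl in place of isopropyl inside the group that now leaves entirely. That step lies beyond the scatter, so replacing the whole group is expected to move the number too. Among the compounds with values here, no measured step covers the amino group, so the direction remains uncertain. The expected change is toward a higher number (a 2.1-fold higher number from compound 2 to compound 3 (0.32 log units; beyond the scatter)). Compound 3 is estimated at 9000 nM (expected range 2500 nM to 30000 nM).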

Compound 3, half-maximal inhibitory concentration: 2540 nM
Beside the measured number, compound 3's estimate is 3.5-fold (0.55 log units) above it; low and high end bracket the measured number.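

At the carbonyl carbon, the ester-type allyloxy group is not needed for activity in this assay: the change to amino gives a 1.7-fold lower number from compound 2 to compound 3 (0.23 log units; within the scatter), so allyloxycarbonyl and carbamoyl cannot be told apart here. The isobutoxy group, in contrast, is separated from amino by a real gap, with an at least 7.8-fold lower number from compound 1 to compound 3 (0.89 log units; beyond the scatter), so the two oxygen-linked chains on this carbon do not behave alike while the bare amino group keeps pace with allyloxy. Compound 1 stands at a limit of the assay, which makes that step a bound and not a measured size: the limit of > 20000 nM in this assay, at which 1 of the 3 values shown sits.

On these data alone, what remains open is whether a substituted nitrogen, such as methylamino or dimethylamino, would behave like amino at this carbon. A short oxygen-linked group such as methoxy, or a longer chain on the nitrogen, is equally unsettled by these compounds.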